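Swapping the Phenol for a Methylsulfonyl Group

The source may hold more compounds than are shown below. What is called first, only, known or untested is meant among the compounds shown, and "the series" means these compounds.

Compound 1 `CC1=C(c2cccc(O)c2)C(c2ccc(OC[C@H](C)N3CC[C@@H](C)C3)cc2)Oc2ccc(O)cc21` gives 0.2 nM in a functional assay on MCF7 cells (Homo sapiens) for antiproliferative activity, read by CellTiter-Glo, with a stated time of 5 days; a higher number here means a weaker inhibitor, a lower number a stronger inhibitor. It stands level with compound 2 `CC1=C(c2cccc(O)c2)C(c2ccc(OC[C@H](C)N3CCCC3)cc2)Oc2ccc(O)cc21`, which gives 0.2 nM, and with compound 3 `CC1=C(c2cccc(O)c2)C(c2ccc(OC[C@H](C)N3CC[C@H](C)C3)cc2)Oc2ccc(O)cc21`, which gives 0.2 nM; the steps of no change at the digits printed from compound 1 to compound 2 (within the scatter) and no change at the digits printed from compound 1 to compound 3 (within the scatter) both stay within the scatter, the second one concerning only (the fact that one of compounds 1 and 3 is drawn with a defined configuration and the other without, at the place where they differ). Compound 4 `CC1=C(c2ccc(S(C)(=O)=O)cc2)C(c2ccc(OC[C@H](C)N3CC[C@@H](C)C3)cc2)Oc2ccc(O)cc21` differs from compound 1 by 4-(methylsulfonyl)phenyl in place of 3-hydroxyphenyl on a double-bonded ring carbon. Among the compounds with values here, none of the measured steps touches this part of the molecule, since all three measured compounds vary only the saturated ring, so they give no guide to the size or direction of this change. Compound 4 is therefore expected, with wide uncertainty, to give 3 nM, within a range from 0.3 nM to 30 nM, an expected step of a 15-fold higher number from compound 1 to compound 4 (1.18 log units; beyond the scatter).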

Compound 4, half-maximal inhibitory concentration: 27 nM
Compound 4: the middle estimate sits 9.0-fold (0.95 log units) below what was measured, and the stated range covers the measured number.
By their numbers in this assay, from the lowest: compounds 1, 2 and 3 (each within the scatter of the next); then compound 4.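

In this assay, within the data shown here, the swap of 3-hydroxyphenyl for 4-(methylsulfonyl)phenyl brings a 140-fold higher number from compound 1 to compound 4 (2.13 log units; beyond the scatter) and is the only step here beyond the scatter. This double-bonded ring carbon therefore matters far more to the read-out than the saturated ring varied across compounds 1, 2 and 3. Nothing recorded here bears on why. Still open, from the compounds shown here alone, is whether losing the hydroxy group or gaining the methylsulfonyl group counts more. A plain phenyl, 4-hydroxyphenyl, 3-(methylsulfonyl)phenyl or an aminophenyl at this carbon would help separate the two.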